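Adding a Third Methoxy Group: Compound 2 to Compound 3

A few compounds are considered here, and "the series" means these few. Any claim that something is new, unique, unknown or untested is made for them only; others in the source may bear on it.

Compound 1 `COc1ccc(/C=C/C2CC=CC(=O)O2)c(OC)c1` and compound 2 `COc1ccc(/C=C/C2CC=CC(=O)O2)cc1OC` share one core and differ only in the placement of their methoxy groups. In a functional assay on MCF7 cells (Homo sapiens) for inhibition, read by sulforhodamine B assay, with a stated time of 48 h (on this read-out higher numbers stand for weaker inhibition of growth and lower numbers for stronger inhibition of growth), compound 1 gives 5.4 uM, and compound 2 gives 7.8 uM; compound 2 holds the higher of the two numbers, though the gap to compound 1 lies within the scatter. Compound 3 `COc1cc(OC)c(OC)cc1/C=C/C1CC=CC(=O)O1` carries methoxy in place of hydrogen on an aromatic carbon. Going by the values given here, no step between measured compounds is known, so the change is expected to bring no shift beyond the scatter, in no clear direction. Compound 3 is expected to give 8 uM, between 3 uM and 20 uM. This estimate implies a step of a 1.0-fold higher number from compound 2 to compound 3 (0.01 log units; within the scatter), expected to lie within the scatter.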

Compound 3, concentration for growth inhibition (reported as GI): 3.8 uM
For compound 3 the middle estimate is 2.1-fold (0.32 log units) above the measured one; the measured number falls inside the stated range.
By their numbers in this assay, from the lowest: compounds 3, 1 and 2 (each within the scatter of the next, the first and the last beyond it).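

Methoxy in place of hydrogen on this aromatic carbon, ortho to a group of 9 heavy atoms, is the first change here to move the number in this assay beyond the scatter, with a 2.1-fold lower number from compound 2 to compound 3 (0.31 log units; beyond the scatter). The same kind of change, read from the other compound, gives a 1.4-fold lower number from compound 1 to compound 3 (0.15 log units; within the scatter), so the shift past the scatter appears from only one of the two starting points. Nothing measured here explains this shift. As far as these compounds go, whether an amine or a hydroxyl group on this carbon would give a similar step remains open, as does the effect of a longer chain such as ethoxy.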